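From compound 2 to its (carboxymethyl)carbamoyl relative, compound 4

The source may hold more compounds than are shown below. What is called first, only, known or untested is meant among the compounds shown, and "the series" means these compounds.

Compound 1 `CCCC/C=C/C=C/[C@@]1(C)SC(O)=CC1=O`: 60 ug/mL
Compound 2 `CCCCCC[C@@]1(C)SC(=O)C=C1OC`: 9.4 ug/mL
Compound 3 `CCCCCCCC[C@@]1(C)SC(=O)C=C1OC`: 16.4 ug/mL

These three numbers all come from a functional assay on MCF7 cells (Homo sapiens) for inhibition, read by radiometric assay and XTT assay (on this read-out higher numbers stand for weaker inhibition and lower numbers for stronger inhibition), and give a first view of the series. Compound 2 and compound 3 cannot be told apart on these numbers and sit at the low end of the set, while compound 1 gives a number clearly higher than that of compound 2.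

The next compound is compound 4 `CCCCCC[C@@]1(C)SC(=O)C=C1OCC(=O)NCC(=O)O`, and the change from compound 2 is (carboxymethyl)carbamoyl in place of hydrogen on a saturated chain carbon bound to an oxygen on an unsaturated carbon in one place: (carboxymethyl)carbamoyl in place of hydrogen on a saturated chain carbon bound to an oxygen on an unsaturated carbon.

For the measured compounds named here, only one measured step is available: a 1.7-fold higher number from compound 2 to compound 3 (0.24 log units; within the scatter), and it is a change elsewhere in the molecule, so it says little about this one. Going by the values given here, no measured step touches the place that changes here. Among the compounds with values here, compound 2 differs from compound 1 in more than one place, and compound 1 at 60 ug/mL shows only that much higher numbers occur. A moderate rise is therefore a cautious expectation rather than a firm one.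

In this assay the expected step is a 2.7-fold higher number from compound 2 to compound 4 (0.42 log units; beyond the scatter) on thin evidence. Compound 4 is estimated at 25 ug/mL with an expected range from 8 ug/mL to 80 ug/mL as a rough guide.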

Compound 4, half-maximal inhibitory concentration: > 80 ug/mL
Compound 4: a limit, no number (the forecaster's own chance of this, stated with the estimate: 15%); middle value at least 3.2-fold (0.50 log units) from the limit.
By their numbers in this assay, from the lowest: compounds 2 and 3 (each within the scatter of the next); then compound 1. At a limit, above all of these: compound 4.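

In this assay compound 4 gives > 80 ug/mL, which is a limit of the assay and not a number. For the compounds shown here, the step can still be read as an at least 8.5-fold higher number from compound 2 to compound 4 (0.92 log units; beyond the scatter), and it shows for the first time that the saturated chain carbon bound to an oxygen on an unsaturated carbon is a place where a change can weaken inhibition clearly, whereas the one earlier single-place step, a 1.7-fold higher number from compound 2 to compound 3 (0.24 log units; within the scatter), lay elsewhere in the molecule. How much weaker compound 4 is stays unknown, and the result rests on the limit alone, which gives no cause for the change: the limit of > 80 ug/mL in this assay, at which 1 of the 4 values shown sits.

On these data alone, whether the weakening belongs to the whole (carboxymethyl)carbamoyl group or only to the carboxylic acid at its end remains open, and a methyl ester at that end, or a simple carbamoyl group in place of the whole, would separate the two. Also open, as far as these compounds go, is whether a small group at this carbon, such as a methyl group or a short chain ending in an amine, would keep inhibition close to that of compound 2 at 9.4 ug/mL.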